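A Methyl Group Joins the Benzyl Ring

The compounds below may be only part of what the source reports. "The series", "measured", "known", "first", "only" and "open" are said of these compounds alone.

Measured so far in a functional assay on T29Kt1 cells (Homo sapiens) for cytotoxicity, read by sulforhodamine B assay, with a stated time of 3 days; on this read-out lower numbers stand for stronger inhibition and higher numbers for weaker inhibition:
compound 1, `OCc1cn(Cc2ccccc2)c2ccccc12`, gives 30 nM
compound 2, `OCc1cn(Cc2ccc(Cl)cc2)c2ccccc12`, gives 79 nM
compound 3, `OCc1cn(Cc2ccc(Br)cc2)c2ccccc12`, gives 390 nM

Compound 1 carries an unsubstituted benzyl group and shows the lowest number of the three, meaning the strongest inhibition. Compound 4, `Cc1cccc(Cn2cc(CO)c3ccccc32)c1`, differs from it by methyl in place of hydrogen on an aromatic carbon.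

Two measured steps are related, since each also puts a group onto the same benzyl ring of compound 1: a 2.6-fold higher number from compound 1 to compound 2 (0.42 log units; beyond the scatter) and a 13-fold higher number from compound 1 to compound 3 (1.11 log units; beyond the scatter). Both raised the number, the smaller group modestly and the larger group strongly, and a 4.9-fold higher number from compound 2 to compound 3 (0.69 log units; beyond the scatter) shows the same ordering. Within the data shown here, no step with a methyl group, and none at a carbon meta to a large group, has been measured, so the direction is borrowed from these chloro and bromo steps. A modest rise in the number, similar in size to the chloro step, is therefore expected for compound 4 in this assay, a 2.0-fold higher number from compound 1 to compound 4 (0.30 log units; within the scatter).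

Compound 4 is estimated at 60 nM, with a likely range from 20 nM to 200 nM.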

Compound 4, half-maximal inhibitory concentration: 1000 nM
Compound 4: middle estimate off by 17-fold (1.22 log units), on the low side; measured number above the stated range.
By their numbers in this assay, from the lowest: compound 1; then compound 2; then compound 3; then compound 4.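

In this assay methyl in place of hydrogen on this aromatic carbon, meta to a large group, gives a 33-fold higher number from compound 1 to compound 4 (1.52 log units; beyond the scatter) and so marks a large loss of inhibition from a single added carbon. That step is larger than a 13-fold higher number from compound 1 to compound 3 (1.11 log units; beyond the scatter) and shows that the number of heavy atoms added does not by itself order these changes, with compound 4 going against the rise seen from the chloro to the bromo compound. No measured evidence is available to explain the size of this rise.

The compounds shown leave open whether the rise belongs to the methyl group itself or to its place on the ring, since the chloro and bromo groups sit at a different carbon. From the compounds shown here alone, how a fluoro group, a methoxy group or an amine would behave at this same carbon also remains open.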